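Changing the chain end of compound 2

The source may report more compounds than this note shows. Statements on the series, on what has been measured and on what is new or still open speak of the compounds shown alone.

- Compound 1 `Nc1nc2cc(-c3nn(CCCC(=O)NO)c4ncnc(N)c34)ccc2o1`: > 150000 nM, a limit
- Compound 2 `Nc1nc2cc(-c3nn(CCCCCCCCC(=O)NO)c4ncnc(N)c34)ccc2o1`: 10200 nM

Among the measured compounds shown here, in a functional assay on HeLa cells (Homo sapiens) for inhibition, read by MTT assay, with a stated time of 72 h (a lower number here means a stronger inhibitor, a higher number a weaker inhibitor), compound 2 gives 10200 nM, the only real number so far. The value for compound 1 is a limit and not a number. Compound 3 `CNC(=O)CCCCCCCn1nc(-c2ccc3oc(N)nc3c2)c2c(N)ncnc21` alters the end of the chain in compound 2: methylcarbamoyl in place of (hydroxycarbamoyl)methyl on a saturated chain carbon, seven bonds along the chain from an aromatic nitrogen. For the measured compounds named here, one measured step bears on this, an at least 14-fold lower number from compound 1 to compound 2 (1.16 log units; beyond the scatter). It is large, and it shows that altering this chain can matter greatly here. Yet both of its compounds keep hydroxycarbamoyl at the chain end, so it does not test the swap to methylcarbamoyl directly. A sizeable move towards weaker inhibition therefore seems likely, and compound 3 may return only a limit. The expected change is a 4.9-fold higher number from compound 2 to compound 3 (0.69 log units; beyond the scatter). For compound 3 the estimated value is 50000 nM, with an expected range of 15000 nM to 150000 nM.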

Compound 3, half-maximal inhibitory concentration: 12900 nM
Compound 3: the middle estimate sits 3.9-fold (0.59 log units) above what was measured, and the stated range ends above it.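

In this assay, the change at the chain end gives a 1.3-fold higher number from compound 2 to compound 3 (0.10 log units; within the scatter), so replacing the hydroxycarbamoyl end with methylcarbamoyl leaves the result indistinguishable, which the earlier step could not show, as both its compounds kept hydroxycarbamoyl. The step of an at least 11-fold lower number from compound 1 to compound 3 (1.06 log units; beyond the scatter) shows that the large difference seen earlier does not depend on hydroxycarbamoyl being at the end of the longer chain, so among these compounds the chain matters more than this end group. For compound 1 the value is a limit and not a number: the limit of > 150000 nM in this assay, at which 1 of the 3 values shown sits.

As far as these compounds go, it remains open whether a carboxylic acid or an amine at the chain end would also leave the number unchanged. A still longer chain might also give a different result, in either direction.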